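Trimming the amide chain of compound 1 to methyl

A few compounds are considered here, and "the series" means these few. Any claim that something is new, unique, unknown or untested is made for them only; others in the source may bear on it.

Among the compounds with values here, compound 1 `Cc1cc(/C=C/C#N)cc(C)c1Oc1cc(Nc2ccc(C#N)cc2)c(N)cc1C(=O)NCCC(F)F` gives 57.6 ug/mL in a physicochemical assay for solubility, read by HPLC, with a stated time of 4 h, at pH 2 (a lower number here means a less soluble compound, a higher number a more soluble compound), the higher of the two numbers measured so far. Compound 2 `COC(=O)c1cc(N)c(Nc2ccc(C#N)cc2)cc1Oc1c(C)cc(/C=C/C#N)cc1C` gives 21.8 ug/mL, and the step of a 2.6-fold lower number from compound 1 to compound 2 (0.42 log units; beyond the scatter) exchanges the whole amide for an ester. Compound 3 `CNC(=O)c1cc(N)c(Nc2ccc(C#N)cc2)cc1Oc1c(C)cc(/C=C/C#N)cc1C` keeps the amide and differs from compound 1 only by hydrogen in place of 2,2-difluoroethyl on a saturated chain carbon bound to an amide-type nitrogen. Within the data shown here, no measured step touches that chain, so the single measured step bears on it only loosely, and any change is expected to stay near the scatter. For compound 3 the estimate is 70 ug/mL, within 30 ug/mL to 160 ug/mL, a step of a 1.2-fold higher number from compound 1 to compound 3 (0.08 log units; within the scatter).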

Compound 3, solubility: 44.7 ug/mL
Estimate against measurement, compound 3: 1.6-fold (0.19 log units) above, within the range that was stated.
By their numbers in this assay, from the lowest: compound 2; then compounds 3 and 1 (each within the scatter of the next).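

Going from 3,3-difluoropropyl to methyl on the amide nitrogen gives a step within the scatter in this assay (a 1.3-fold lower number from compound 1 to compound 3 (0.11 log units; within the scatter)), so the fluorinated chain can be cut back to methyl with no readable change here. The short amide also stands apart from the ester (a 2.1-fold higher number from compound 2 to compound 3 (0.31 log units; beyond the scatter)), a step beyond the scatter, just as the longer amide did. Nothing measured here gives a reason for either step.

Still open, as far as these compounds go, is whether an amine or a carboxylic acid at the end of this chain would move the number beyond the scatter. A longer chain without fluorine is equally untested among these compounds.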